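The source may hold more compounds than are shown below. What is called first, only, known or untested is meant among the compounds shown, and "the series" means these compounds.

Of the compounds shown here, two of one shared core have been tested for how strongly they inhibit the enzyme. Compound 1 `CC(C)n1nc(-c2ccccc2)c(-c2ccccc2)cc1=O` gives 152000 nM in an assay on microsomes from liver for inhibition of sterol O-acyltransferase 1 (Rattus norvegicus); a lower number here means a stronger inhibitor, a higher number a weaker inhibitor. Compound 2 `CCCCCCn1nc(-c2ccccc2)c(-c2ccccc2)cc1=O` carries a hexyl chain in place of the isopropyl group on the ring nitrogen and gives 57000 nM in this assay, a 2.7-fold lower number from compound 1 to compound 2 (0.43 log units; beyond the scatter). Compound 2 thus shows the lower of the two numbers, the stronger inhibition of the pair.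

Compound 3 `CCCCCCn1nc(-c2ccccc2)c(-c2ccccc2)c(C)c1=O` differs from compound 2 by methyl in place of hydrogen on an aromatic carbon. For the measured compounds named here, the only measured step, from compound 1 to compound 2, concerns the chain on the ring nitrogen and not a substituent on a ring carbon, so it says little about this change. Going by the values given here, with no closely related step to lean on, the expectation for compound 3 is a change of about no change at the digits printed from compound 2 to compound 3 (within the scatter), that is, no step beyond the scatter. Compound 3 is therefore estimated at 57000 nM, with a likely range from 20000 nM to 160000 nM.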

Compound 3, half-maximal inhibitory concentration: 56000 nM
Compound 3: middle estimate off by 1.0-fold (0.01 log units), on the high side; the measured number falls inside the stated range.
By their numbers in this assay, from the lowest: compounds 3 and 2 (each within the scatter of the next); then compound 1.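

In this assay, a methyl group in place of hydrogen on this ring carbon, the one opposite the ring nitrogen, gives a step that stays inside the scatter (a 1.0-fold lower number from compound 2 to compound 3 (0.01 log units; within the scatter)). For the compounds shown here, this is the first look at a ring carbon of the shared core, and it shows that, with the hexyl group on the ring nitrogen, this position takes a methyl group with no measurable effect on the number. Nothing measured here offers an explanation for this result.

A single small group cannot show whether this carbon would tolerate something larger or of another kind, such as a longer chain, a phenyl group, an amine or a carboxylic acid. On these data alone, it also remains open whether the methyl group would behave the same way with isopropyl on the ring nitrogen.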